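A few compounds are considered here, and "the series" means these few. Any claim that something is new, unique, unknown or untested is made for them only; others in the source may bear on it.

Compound 1 `COc1ccc(/C=C/C(=O)CC(C)=O)cc1OC`: 8200 nM
Compound 2 `COc1ccc(/C=C/C(=O)CC(C)=O)cc1`: 9100 nM
Compound 3 `Cc1cc(/C=C/c2ccc(O)c(O)c2)on1`: 10500 nM

In a functional assay on DU-145 cells (Homo sapiens) for cytotoxicity, read by MTT assay, with a stated time of 72 h (on this read-out lower numbers stand for stronger inhibition and higher numbers for weaker inhibition), compound 2 gives 9100 nM, which lies within the usual scatter of both compound 1 and compound 3, so these three values have no meaningful order. Compound 4 `CC(=O)CC(=O)/C=C/c1ccc(O)cc1` differs from compound 2 by hydrogen in place of methyl on an oxygen on an aromatic ring. Among the compounds with values here, only one measured step bears on this, and it is a different change, hydrogen in place of methoxy on an aromatic carbon: a 1.1-fold higher number from compound 1 to compound 2 (0.05 log units; within the scatter). That small step gives no reason to expect a large one here. The expected step is a 1.1-fold higher number from compound 2 to compound 4 (0.04 log units; within the scatter), with no change expected beyond the scatter. The estimate for compound 4 is 10000 nM, with an expected range of 5000 nM to 20000 nM.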

Compound 4, half-maximal inhibitory concentration: 8800 nM
Estimate against measurement, compound 4: 1.1-fold (0.06 log units) above, and the stated range covers the measured number.
By their numbers in this assay, from the lowest: compounds 1, 4, 2 and 3 (each within the scatter of the next).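

In this assay, the change from methoxy to hydroxy on the aromatic ring gives a 1.0-fold lower number from compound 2 to compound 4 (0.01 log units; within the scatter) and so stays within the scatter. The earlier step removed a whole methoxy group from an aromatic carbon, whereas this one shows that the oxygen on the ring can carry either methyl or hydrogen with no readable difference. Nothing shown gives a reason for this. Still open, as far as these compounds go, is whether a larger group on this oxygen, such as ethyl or benzyl, or an amine in place of the oxygen, would move the number beyond the scatter.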